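Ring Enlargement at the Chain End of Compound 2

A few compounds are considered here, and "the series" means these few. Any claim that something is new, unique, unknown or untested is made for them only; others in the source may bear on it.

Of the compounds shown here, two have been measured. Compound 1 `CC(C)CCCCCCCCC(=O)N(O)CCC(=O)O` gives 24000 nM in an assay on isolated protein for inhibition of histone lysine demethylase PHF8 (Homo sapiens), read by mass spectrometry, with a stated time of 1 h (a higher number here means a weaker inhibitor, a lower number a stronger inhibitor), and compound 2 `O=C(O)CCN(O)C(=O)CCCCCCCCC1CCCCC1` gives 17000 nM in the same assay. Within the data shown here, the single step between them, a 1.4-fold lower number from compound 1 to compound 2 (0.15 log units; within the scatter), comes from a cyclohexyl in place of an isopropyl on a saturated chain carbon, eight bonds along the chain from a carbonyl carbon. Compound 2 and compound 1 therefore sit within the scatter of each other, and neither stands apart on the numbers shown.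

Compound 3 `O=C(O)CCN(O)C(=O)CCCCCCCCC1CCCCCC1` carries the same chain with a larger ring at its end: cycloheptyl in place of cyclohexyl on a saturated chain carbon, eight bonds along the chain from a carbonyl carbon. Among the measured compounds shown here, the only measured step that bears on this change is the one from compound 1 to compound 2, which altered the saturated group at this very place and did not move the number beyond the scatter. On that basis compound 3 is expected to give a step of about a 1.2-fold lower number from compound 2 to compound 3 (0.08 log units; within the scatter), that is, none beyond the scatter. Compound 3 is estimated at 14000 nM in this assay, with a range from 6000 nM to 35000 nM.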

Compound 3, half-maximal inhibitory concentration: 9100 nM
Compound 3: the middle estimate sits 1.5-fold (0.19 log units) above what was measured; the range from low to high includes it.
By their numbers in this assay, from the lowest: compounds 3, 2 and 1 (each within the scatter of the next, the first and the last beyond it).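

At this place, on a saturated chain carbon, eight bonds along the chain from a carbonyl carbon, enlarging the ring from cyclohexyl to cycloheptyl gives a 1.9-fold lower number from compound 2 to compound 3 (0.27 log units; within the scatter), so this change alone does not separate the two compounds. Cycloheptyl in place of isopropyl gives a 2.6-fold lower number from compound 1 to compound 3 (0.42 log units; beyond the scatter), the first step at this place to clear the scatter, which shows that the group here can shift the number, though only modestly and only across the full span from isopropyl to cycloheptyl. No evidence accompanies these numbers that would account for either step.

From the compounds shown here alone, the three end groups are all saturated and made of carbon only, so it remains open how a phenyl ring, an amine or a carboxylic acid at the chain end would read, and whether a cyclooctyl ring would lower the number further or give it back. Also open, going by these compounds, is whether cycloheptyl would keep this modest gain on a shorter or longer chain, since the chain length stays the same in all three compounds.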